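Cyanobenzyl for Methylbenzyl in a Cytotoxicity Series

The source may hold more compounds than are shown below. What is called first, only, known or untested is meant among the compounds shown, and "the series" means these compounds.

Compound 1 `COC(=O)c1ccc(NCc2cncn2Cc2cccc(C)c2)cc1-c1ccccc1`: > 10000 nM
Compound 2 `c1ccc(-c2ccc(Cn3cncc3CNc3cccc(-c4ccccc4)c3)cc2)cc1`: 10000 nM

In a toxicity assay on NIH3T3 cells (Mus musculus) for cytotoxicity, read by resazurin assay (on this read-out higher numbers stand for an effect only at larger amounts of compound and lower numbers for an effect already at smaller amounts), compound 1 gives only a limit, > 10000 nM. In this assay compound 2 gives 10000 nM. Compound 1 thus stands at the limit of > 10000 nM in this assay, at which 1 of the 2 values shown sits, with no number of its own to anchor a step. Compound 3 `COC(=O)c1ccc(NCc2cncn2Cc2ccccc2C#N)cc1-c1ccccc1` differs from compound 1 by 2-cyanophenyl in place of 3-methylphenyl on a saturated chain carbon bound to an aromatic nitrogen. For the measured compounds named here, no measured pair shows what this exchange does here, so no step beyond the usual scatter of this assay is expected, and a number no higher from compound 1 to compound 3 (the limit leaves the size open) is an estimate only. Compound 3 is therefore expected at 10000 nM, between 4000 nM and 25000 nM, most probably reported again only as a limit.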

Compound 3, half-maximal effective concentration: 25000 nM
The estimate for compound 3 lay 2.5-fold (0.40 log units) below the measured number; measured number inside the range.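

Compound 1 carries only a limit in this assay, so no step to compound 3 can be read: the limit of > 10000 nM in this assay, at which 1 of the 3 values shown sits.

The compounds shown leave open what size of effect, if any, 2-cyanophenyl in place of 3-methylphenyl has on this read-out.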